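This account rests on a few compounds, and the source may have more. Where it says the series, first, only, none or still open, it means among the compounds named here.

The measured compounds:
compound 1, `Cc1ncc([N+](=O)[O-])n1CC(O)CN1CCCCC1`: in a toxicity assay on HeLa cells (Homo sapiens) for cytotoxicity, read by MTT assay, with a stated time of 24 h (on this read-out higher numbers stand for weaker inhibition and lower numbers for stronger inhibition), compound 1 gives > 5000000 nM, which is a limit of the assay and not a number.
compound 2, `Cc1ncc([N+](=O)[O-])n1CC(O)CN1CCC(C)CC1`: in this assay compound 2 gives > 5000000 nM, again a limit of the assay and not a number.

Both values sit at the same limit, (the limit of > 5000000 nM in this assay, at which 2 of the 2 values shown sit), so compound 2 stands at that limit and nowhere more exactly; the step that the two limits leave unreadable from compound 1 to compound 2 cannot be read, and nothing can be said about order between compound 1 and compound 2.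

Compound 3, `Cc1ncc([N+](=O)[O-])n1CC(O)CN1CCC(Cc2ccccc2)CC1`, differs from compound 2 by phenyl in place of hydrogen on a saturated chain carbon bound to a saturated ring carbon. Going by the values given here, the one measured step concerns a saturated ring carbon of the same ring and is itself unreadable, so it gives no size and no direction to carry over to this larger change. Among the compounds with values here, what the data support is only that both measured compounds fall at the limit.

Compound 3 is therefore expected to give 5000000 nM in this assay, within an estimated range from 1000000 nM to 20000000 nM. This estimate means a step of a number no higher from compound 2 to compound 3 (the limit leaves the size open), with a fair chance that only a limit is reported again.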

Compound 3, half-maximal inhibitory concentration: 1430000 nM
Compound 3: the middle estimate sits 3.5-fold (0.54 log units) above what was measured; the measured number falls inside the stated range.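

With benzyl on the saturated ring carbon, the read-out in this assay moves off the limit for the first time, which neither hydrogen nor methyl on that ring had done, and the other two values are limits and not numbers: the limit of > 5000000 nM in this assay, at which 2 of the 3 values shown sit.

Methyl to benzyl gives an at least 3.4-fold lower number from compound 2 to compound 3 (0.54 log units; beyond the scatter), and benzyl in place of hydrogen gives an at least 3.4-fold lower number from compound 1 to compound 3 (0.54 log units; beyond the scatter); both steps are beyond the usual scatter, and each starts from a limit, so its full size stays unknown. Since lower numbers here stand for stronger inhibition, this position tolerates a change that gives a readable and stronger effect on these cells, and adding phenyl to the saturated chain carbon bound to a saturated ring carbon is the first change shown to do so.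

The compounds shown leave open whether the aromatic ring itself matters or whether a cyclohexyl group or a longer chain on the same ring carbon would give a similar number. They also leave open how an amine or a carboxylic acid on the phenyl ring would shift the value of compound 3.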